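A Single Stereocentre Redrawn in a Cytotoxicity Series

The compounds below may be only part of what the source reports. "The series", "measured", "known", "first", "only" and "open" are said of these compounds alone.

Compound 1 `CC1=C(CC(=O)N2CCN(c3ccncc3)CC2)c2cc(F)ccc2/C1=C\c1ccc([S+](C)[O-])cc1` gives 9200 nM
Compound 2 `COC(=O)[C@@H](C)NC(=O)CC1=C(C)/C(=C/c2ccc(SC)cc2)c2ccc(F)cc21` gives 16200 nM

In a functional assay on HT-29 cells (Homo sapiens) for inhibition, read by CellTiter-Glo, with a stated time of 72 h (on this read-out lower numbers stand for higher toxicity in this test and higher numbers for lower toxicity in this test), compound 2 stands at 16200 nM and compound 1 stands at 9200 nM, so the two numbers lie within the usual scatter of each other and neither can be ranked over the other.

Compound 3 `COC(=O)[C@H](C)NC(=O)CC1=C(C)/C(=C/c2ccc(SC)cc2)c2ccc(F)cc21` has not yet been measured. It has the same atoms and bonds as compound 2 and differs only in configuration as drawn: the two compounds have the same atoms and bonds and differ only in configuration as drawn: 1 of 2 stereo elements differ; a stereocentre at a saturated chain carbon is drawn R in compound 2 and S in compound 3. A stereocentre at a saturated chain carbon is drawn R in compound 2 and S in compound 3.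

Among the compounds with values here, no two measured compounds differ in one place, so the numbers offer no direct guide to what such a change does in this assay. With compound 2 at 16200 nM as the closest reference, no shift in either direction beyond the scatter is expected. The expected size is a 1.1-fold lower number from compound 2 to compound 3 (0.03 log units; within the scatter), which stays within the scatter. For compound 3 the estimated value is 15000 nM, with an expected range from 6000 nM to 35000 nM, and the measurement is still to come.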

Compound 3, half-maximal cytotoxic concentration: 23900 nM
Compound 3: the middle estimate sits 1.6-fold (0.20 log units) below what was measured; low and high end bracket the measured number.
By their numbers in this assay, from the lowest: compounds 1, 2 and 3 (each within the scatter of the next, the first and the last beyond it).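

Inverting the stereocentre at a saturated chain carbon, drawn R and then S, gives in this assay a 1.5-fold higher number from compound 2 to compound 3 (0.17 log units; within the scatter). Within the data shown here, the earlier values offered no pair that differed in one place, so this is the first direct reading of any change, and it shows that the two configurations at this carbon cannot be ranked against each other in this test. Whatever small gap the two numbers show, the comparison is a clean one, resting on a single feature: the fact that compounds 2 and 3 differ only in the configuration as drawn.

Going by these compounds, one pair speaks only for this one side chain and this one ester, so it remains open whether the configuration would still make so little difference with a larger group on the stereocentre, such as an isopropyl or a benzyl in place of the methyl. Also open, on these data alone, is what a free carboxylic acid in place of the methyl ester would do in either configuration, and whether the two forms would then separate beyond the scatter.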